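Adding a Phenyl to the Amide Nitrogen of Compound 3

The source may report more compounds than this note shows. Statements on the series, on what has been measured and on what is new or still open speak of the compounds shown alone.

Compound 1 `O=C(Nc1ccc(OC(F)(F)F)cc1)c1cc(Cl)ccc1O` gives 7300 nM in an ADME assay on cells (Macrophage, Mus musculus) for cytotoxicity, read by resazurin assay, with a stated time of 3 days; a higher number here means a weaker inhibitor, a lower number a stronger inhibitor. Compound 2 `CC(C)(C)c1ccc(NC(=O)c2cc(Cl)ccc2O)cc1` gives 19000 nM in this assay, a 2.6-fold higher number from compound 1 to compound 2 (0.42 log units; beyond the scatter). Compound 3 `NC(=O)c1ccc(NC(=O)c2cc(Cl)ccc2O)cc1` reaches only a limit of this assay, > 60000 nM. Compound 3 therefore stands at the limit of > 60000 nM in this assay, at which 1 of the 3 values shown sits, the weakest-looking of the three, since an at least 8.2-fold higher number from compound 1 to compound 3 (0.91 log units; beyond the scatter) and an at least 3.1-fold higher number from compound 2 to compound 3 (0.49 log units; beyond the scatter) both lie beyond the scatter.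

Compound 4 `O=C(Nc1ccccc1)c1ccc(NC(=O)c2cc(Cl)ccc2O)cc1` differs from compound 3 by phenyl in place of hydrogen on an amide-type nitrogen. Among the compounds with values here, no measured step touches this amide nitrogen; the closest bearing comes from an at least 3.1-fold higher number from compound 2 to compound 3 (0.49 log units; beyond the scatter) and an at least 8.2-fold higher number from compound 1 to compound 3 (0.91 log units; beyond the scatter), which show the carbamoyl compound giving the highest number. A step back toward lower numbers is expected, sized as an at least 1.7-fold lower number from compound 3 to compound 4 (0.23 log units; that floor lies within the scatter), though from a limit it cannot be fixed. Compound 4 is estimated at 35000 nM, between 9000 nM and 120000 nM.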

Compound 4, half-maximal inhibitory concentration: > 60000 nM
Compound 4: only a limit was reported (the forecaster's own chance of this, stated with the estimate: 40%); middle value at least 1.7-fold (0.23 log units) away from the limit.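

Within the data shown here, compound 3 and compound 4 both reach only a limit of this assay, so no step between them can be read: the limit of > 60000 nM in this assay, at which 2 of the 4 values shown sit. On these data alone, whether phenyl in place of hydrogen on the amide-type nitrogen changes the number at all stays open.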